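The source may report more compounds than this note shows. Statements on the series, on what has been measured and on what is new or still open speak of the compounds shown alone.

Measured so far:
Compound 1, `CCOC(=O)CCCCCOc1ccc(CNC(C)C)cc1`, in an ADME assay on BJ cells (Homo sapiens) for cytotoxicity, read by CellTiter-Glo and resazurin assay, with a stated time of 72 h (on this read-out higher numbers stand for an effect only at larger amounts of compound and lower numbers for an effect already at smaller amounts), gives > 26000 nM, which is a limit of the assay and not a number.
Compound 2, `CCCNCc1ccc(OCCCCCC(=O)OCC)cc1`, in this assay gives > 26000 nM, likewise a limit of the assay.

For the measured compounds named here, compound 2 thus stands at the limit of this assay, and the one further value shown is a limit as well. Going by the values given here, the only measured step, a step that the two limits leave unreadable from compound 1 to compound 2, cannot be read in size because both of its ends sit at the limit of > 26000 nM in this assay, at which 2 of the 2 values shown sit.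

Compound 3, `CCOC(=O)CCCCCOc1ccc(C=O)cc1`, differs from compound 2 by formyl in place of (propylamino)methyl on an aromatic carbon. No measured step concerns a change of this kind, and the single step shown is itself unreadable, so the expectation for compound 3 rests only on where compound 2 stands. Compound 3 is expected to give 30000 nM in this assay, with a range from 10000 nM to 100000 nM. The expected step that the limit leaves unreadable from compound 2 to compound 3 means no change beyond the scatter is anticipated, and a limit is again the likelier result.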

Compound 3, half-maximal effective concentration: > 26000 nM
Compound 3: a limit, no number (the forecaster's own chance of this, stated with the estimate: 70%); the middle value does not contradict the limit.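

In this assay compound 3 gives > 26000 nM as a limit of the assay and not a number. For the compounds shown here, no new step among compound 1, compound 2 and compound 3 can be read. Left open is whether formyl, (propylamino)methyl or (isopropylamino)methyl changes the concentration needed for an effect in this assay at all.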